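Methoxy on the anilino ring of sulfonylquinoxalines

The source may report more compounds than this note shows. Statements on the series, on what has been measured and on what is new or still open speak of the compounds shown alone.

The series rests on a quinoxaline bearing an arylsulfonyl group and an anilino group. Compound 1 `O=S(=O)(c1ccccc1)c1nc2ccccc2nc1Nc1ccccc1` is the plainest member, and in a functional assay on HL-60 cells (Homo sapiens) for cytotoxicity, read by MTT assay, with a stated time of 72 h (on this read-out lower numbers stand for stronger inhibition and higher numbers for weaker inhibition), compound 1 gives 140 nM. Compound 2 `COc1ccc(Nc2nc3ccccc3nc2S(=O)(=O)c2ccccc2)cc1` carries one added group, described as methoxy in place of hydrogen on an aromatic carbon, and in this assay compound 2 gives 640 nM; the step of a 4.6-fold higher number from compound 1 to compound 2 (0.66 log units; beyond the scatter) thus weakened the compound. Compound 3 `COc1cc(Nc2nc3ccccc3nc2S(=O)(=O)c2ccc(C)cc2)cc(OC)c1` differs from compound 1 in more than one place, so the difference between the two cores is not broken down here; in this assay compound 3 gives 20 nM, the lowest of the three numbers.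

Compound 4 `COc1cc(Nc2nc3ccccc3nc2S(=O)(=O)c2ccc(C)cc2)cc(OC)c1OC` has not yet been measured in this assay. It differs from compound 3 by methoxy in place of hydrogen on an aromatic carbon. Within the data shown here, this is the same kind of change as the one from compound 1 to compound 2, but not the same: in compound 4 the entering group sits ortho to two methoxy groups, whereas in compound 2 no such neighbours are recorded. Among the measured compounds shown here, with only one earlier instance, the direction of the earlier step is the sole guide. The expected step of a 2.5-fold higher number from compound 3 to compound 4 (0.40 log units; beyond the scatter) is set beside a 4.6-fold higher number from compound 1 to compound 2 (0.66 log units; beyond the scatter), somewhat softened since the surroundings differ. Compound 4 is therefore estimated to give 50 nM, with a likely range from 12 nM to 200 nM.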

Compound 4, half-maximal inhibitory concentration: 320 nM
Compound 4: the middle estimate sits 6.4-fold (0.81 log units) below what was measured; measured number above the stated range.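

In this assay, methoxy in place of hydrogen on an aromatic carbon again went with a higher number, a 16-fold higher number from compound 3 to compound 4 (1.20 log units; beyond the scatter), so the direction of the change was the same on both cores, though two pairs are too few to call this a rule for the series. The size of the step did not carry over from one core to the other: the two steps lie further apart than repeated measurements would explain: the same change on two cores in this assay, a 4.6-fold higher number (0.66 log units; beyond the scatter) from compound 1 to compound 2 and a 16-fold higher number (1.20 log units; beyond the scatter) from compound 3 to compound 4, 3.5-fold (0.54 log units) apart, beyond the scatter of two such steps. What this does not show is where the gap comes from, since the pairs differ in the surroundings of the entering group, which in compound 4 sits ortho to two methoxy groups, and also elsewhere in the core, and the data do not separate these differences.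

The compounds shown leave open whether the higher number belongs to methoxy itself or would also appear with a hydroxy group, a fluorine atom or an ethoxy group on the same carbon. They also leave open whether an amine or a carboxylic acid at that place would give a step of the same direction on either core.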